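Series notes: methoxy to hydroxy on compound 3

A few compounds are considered here, and "the series" means these few. Any claim that something is new, unique, unknown or untested is made for them only; others in the source may bear on it.

Measured compounds:
compound 1 `COc1cc(C)cc(-c2nn(CC#N)cc2-c2ccc(-c3cccc(C(C)=O)c3)nc2)c1` gives 92% in a functional assay on OVCAR-4 cells (Homo sapiens) for cytotoxicity, read by sulforhodamine B assay, with a stated time of 48 h, tested at 100 nM; a higher number here means a weaker effect of the compound at the concentration tested, a lower number a stronger effect
compound 2 `Cc1cc(O)cc(-c2nn(CC#N)cc2-c2ccnc(-c3ccc(Oc4ccccc4)cc3)c2)c1` gives 106% in this assay
compound 3 `COc1cc(C)cc(-c2nn(CC#N)cc2-c2ccnc(-c3ccc(N(C)C)cc3)c2)c1` gives 33% in this assay

Compound 3 holds the lowest number of the three in this assay. Its nearest neighbour by value is compound 1, which sits higher by a margin beyond the usual scatter; compound 2 sits higher still, again beyond the scatter. Compound 3 is thus the only one of the three that shows a clear effect at the concentration tested.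

The next compound, compound 4 `Cc1cc(O)cc(-c2nn(CC#N)cc2-c2ccnc(-c3ccc(N(C)C)cc3)c2)c1`, differs from compound 3 in one place: hydrogen in place of methyl on an oxygen on an aromatic ring. The change sits on the aromatic ring attached to the shared core, away from the dimethylaminophenyl side that compound 3 and compound 4 have in common.

Among the measured compounds shown here, no pair of measured compounds differs only in this way, so the three values give no direct reading of what the change does. Compound 2 carries the hydroxy, but also a different pyridine substituent, and its high number cannot be separated from that second difference. The expectation for compound 4 is therefore drawn mainly from compound 3, with wide uncertainty in either direction. A modest weakening is expected for the step of a number 15 percentage points higher from compound 3 to compound 4 (beyond the scatter), though a step within the scatter would not be surprising. Compound 4 is estimated at 48%, with a range from 20% to 95%.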

Compound 4, a percentage reported as activity, at one concentration (the size of the read-out at that concentration, not a potency): 101%
Compound 4: middle estimate off by 53 percentage points, on the low side, outside the stated range (above it).
By their numbers in this assay, from the lowest: compound 3; then compounds 1, 4 and 2 (each within the scatter of the next, the first and the last beyond it).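

In this assay, among the compounds shown here, the change from methoxy to hydroxy on the 3-methoxy-5-methylphenyl group gives the first direct reading at this position, a number 68 percentage points higher from compound 3 to compound 4 (beyond the scatter), and this one change is enough to separate the two compounds. The dimethylaminophenyl group, which compound 3 and compound 4 share, therefore does not carry the effect on its own, and the oxygen substituent on the aromatic ring matters in this pair. With the hydroxy held constant, dimethylamino in place of phenoxy on an aromatic carbon gives a number 5 percentage points lower from compound 2 to compound 4 (within the scatter), so that exchange shows no separation in this pair, and no measurement at hand accounts for either step.

As far as these compounds go, it remains open whether the effect requires methoxy itself or would persist with an ethoxy, a longer alkoxy chain or an amine in its place on the same ring. Also unresolved is whether phenoxy and dimethylamino would differ with methoxy in place, and whether the step seen at this single concentration would hold at other concentrations.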